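Swapping methyl for chloro on the outer ring

This account rests on a few compounds, and the source may have more. Where it says the series, first, only, none or still open, it means among the compounds named here.

Compound 1 `Cc1cccc(Oc2ccc(N3CCC[C@H]3CC(=O)O)cc2)c1` carries a 3-methylphenyl on the oxygen, and in a functional assay on cells for agonist activity at Free fatty acid receptor 1 (Mus musculus), read by FLIPR and calcium flux, with a stated time of 100 s (on this read-out lower numbers stand for an effect already at smaller amounts and higher numbers for an effect only at larger amounts of compound), compound 1 gives 2400 nM. Compound 2 `O=C(O)C[C@@H]1CCCN1c1ccc(Oc2cccc(Cl)c2)cc1` bears chloro in place of that methyl. In this assay compound 2 reaches only a limit of the assay, > 16000 nM, so its number is not known beyond that. The exchange gives an at least 6.6-fold higher number from compound 1 to compound 2 (0.82 log units; beyond the scatter). Compound 3 `Cc1ccc(Oc2ccc(N3CCC[C@H]3CC(=O)O)cc2)cc1` instead carries a 4-methylphenyl. In this assay compound 3 likewise stands at a limit of the assay, > 33000 nM. Moving the methyl gives an at least 13-fold higher number from compound 1 to compound 3 (1.13 log units; beyond the scatter), while the gap from compound 2 to compound 3 is a step that the two limits leave unreadable from compound 2 to compound 3. Compound 4 `O=C(O)C[C@@H]1CCCN1c1ccc(Oc2ccc(Cl)cc2)cc1` differs from compound 3 by chloro in place of methyl on an aromatic carbon. For the measured compounds named here, the one measured step of the same kind, an at least 6.6-fold higher number from compound 1 to compound 2 (0.82 log units; beyond the scatter), pushed the number up beyond the scatter, and compound 3 already sits at a limit. Compound 4 is therefore expected to stay at or beyond a limit, an estimated step that the limit leaves unreadable from compound 3 to compound 4, giving an estimate of 60000 nM within the range 20000 nM to 200000 nM.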

Compound 4, half-maximal effective concentration: > 33000 nM
Compound 4 gave a limit, no number; the forecaster's own chance of this, stated with the estimate: 85%; the middle value lies beyond the limit too.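

Compound 4 joins compound 3 at the same limit of the assay, a limit and not a number: the limit of > 33000 nM in this assay, at which 2 of the 4 values shown sit.

With a 4-chlorophenyl, as with a 4-methylphenyl, no readable number appears, so swapping methyl for chloro at this place gives no measured value, and the steps from compound 3 and from compound 2 to compound 4 cannot be read. The one readable step is an at least 13-fold higher number from compound 1 to compound 4 (1.13 log units; beyond the scatter), which leaves the 3-methylphenyl as the only outer group of the four shown with a measured number.

On these data alone, whether a methoxy or a nitrile in place of the methyl of compound 1 would give a readable number stays open. Also open, as far as these compounds go, is how far compound 2, compound 3 and compound 4 lie past their limits.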